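Changing the Aryl Group on the Ring Nitrogen

The source may report more compounds than this note shows. Statements on the series, on what has been measured and on what is new or still open speak of the compounds shown alone.

Compound 2 `COc1cc(F)ccc1N1C(=O)CSC1c1cccc(C(=O)NCCCCc2ccccc2)c1` gives 63% in a functional assay on 143B cells (Homo sapiens) for inhibition, read by CCK-8 assay, with a stated time of 72 h, tested at 1 uM (a higher number here means more inhibition at the concentration tested (going by the name of the read-out), a lower number less inhibition), the higher of the two measured numbers; compound 1 `COc1ccc(C)cc1N1C(=O)CSC1c1cccc(C(=O)NCCCCc2ccccc2)c1` gives 29%. Compound 3 `O=C(NCCCCc1ccccc1)c1cccc(C2SCC(=O)N2c2cccc(F)c2)c1` differs from compound 2 in one place: 3-fluorophenyl in place of 4-fluoro-2-methoxyphenyl on an amide-type nitrogen in a ring. Within the data shown here, the single measured step concerns the same position: a number 34 percentage points higher from compound 1 to compound 2 (beyond the scatter). That step shows that the group on the amide-type nitrogen in a ring can shift the read-out strongly, but it does not show which way a 3-fluorophenyl will act, so a step in either direction beyond the scatter is possible. Compound 3 is therefore expected to give 45%, between 20% and 70%, an expected step of a number 18 percentage points lower from compound 2 to compound 3 (beyond the scatter).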

Compound 3, a percentage reported as inhibition, at one concentration (the size of the read-out at that concentration, not a potency): 63%
The estimate for compound 3 lay 18 percentage points below the measured number; the range from low to high includes it.
By their numbers in this assay, from the lowest: compound 1; then compounds 2 and 3 (each within the scatter of the next).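

Replacing 4-fluoro-2-methoxyphenyl with 3-fluorophenyl on the ring nitrogen gives no change at the digits printed from compound 2 to compound 3 (within the scatter) in this assay. The methoxy group is therefore not needed to keep this level of inhibition, although the fluorine also sits differently in these two groups. The 3-fluorophenyl group also gives a number 34 percentage points higher from compound 1 to compound 3 (beyond the scatter), so both fluorine-bearing groups stand clear of 2-methoxy-5-methylphenyl. Nothing measured here explains these results. As far as these compounds go, whether the fluorine itself matters remains open, as does how an unsubstituted phenyl or an aminophenyl group would behave at this position.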